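Side-chain variation on the shared core: hydroxyl removed

A few compounds are considered here, and "the series" means these few. Any claim that something is new, unique, unknown or untested is made for them only; others in the source may bear on it.

Measured so far:
- compound 1 `Cn1ncc(Cl)c1-c1cc(C(=O)N[C@@H]2CN[C@H](CCCO)C[C@H]2c2ccc(Cl)c(Cl)c2)oc1Cl`: 210 nM
- compound 2 `Cn1ncc(Cl)c1-c1cc(C(=O)N[C@@H]2CN[C@H](CCO)C[C@H]2c2ccc(F)c(F)c2)oc1Cl`: 60 nM

Both measured compounds were run in a functional assay on LNCaP cells (Homo sapiens) for antiproliferative activity; a lower number here means a stronger inhibitor, a higher number a weaker inhibitor. Of the two numbers, compound 1 stands at the higher end with 210 nM, while compound 2 gives 60 nM; the two values lie beyond the scatter of each other, but the compounds differ in more than one place, so no single step can be read from them.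

Compound 3 `C=CC[C@@H]1C[C@@H](c2ccc(Cl)c(Cl)c2)[C@H](NC(=O)c2cc(-c3c(Cl)cnn3C)c(Cl)o2)CN1` is not yet measured. It differs from compound 1 only in the side chain: vinyl in place of 2-hydroxyethyl on a saturated chain carbon bound to a saturated ring carbon. The hydroxyl carried by compound 1 is thereby lost, and the chain is shortened by one heavy atom.

Within the data shown here, no measured pair in this small set isolates such a change, so the direction rests on the structural change alone. A modest step is expected, most likely toward a somewhat higher number than that of compound 1, though a step within the scatter cannot be excluded; the expected step is a 1.5-fold higher number from compound 1 to compound 3 (0.18 log units; within the scatter). For compound 3 the estimate in this assay is 320 nM, with a range from 110 nM to 950 nM.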

Compound 3, half-maximal inhibitory concentration: 160 nM
The estimate for compound 3 lay 2.0-fold (0.30 log units) above the measured number; low and high end bracket the measured number.
By their numbers in this assay, from the lowest: compound 2; then compounds 3 and 1 (each within the scatter of the next).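

In this assay, vinyl in place of 2-hydroxyethyl on a saturated chain carbon bound to a saturated ring carbon gives a 1.3-fold lower number from compound 1 to compound 3 (0.12 log units; within the scatter). Among these compounds, this is the first single-place step, and it shows that, on the core of compound 1, this position tolerates the loss of the hydroxyl, with its hydrogen-bond donor and acceptor, and the entry of a double bond without a change beyond the scatter. Nothing measured here accounts for this result.

From the compounds shown here alone, compound 2 differs from both compound 1 and compound 3 in more than one place, so its steps to them cannot be read, and the side chain's share in its separate position remains unknown. The hydroxyl loss and the double-bond entry also arrive together in this one step, which leaves open whether a saturated propyl chain would track with compound 3, and whether an amine or a carboxylic acid at the chain end would keep the number within the scatter of compound 1 at 210 nM.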